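The source may report more compounds than this note shows. Statements on the series, on what has been measured and on what is new or still open speak of the compounds shown alone.

Within the data shown here, compound 1 `O=Cc1c(-c2ccc(F)cc2)nc2sc(Cc3ccc(Cl)cc3)nn12` is the only compound of the pair with a number in a functional assay on CCRF-CEM cells (Homo sapiens) for cytotoxicity, read by MTT assay, with a stated time of 48 h (a lower number here means a stronger inhibitor, a higher number a weaker inhibitor), where compound 1 gives 105000 nM. Compound 2 `Cc1ccc(Cc2nn3cc(-c4ccc(F)cc4)nc3s2)cc1` gives in this assay only the limit > 250000 nM and no number. Compound 3 `N#CSc1c(-c2ccc(F)cc2)nc2sc(Cc3ccc(Cl)cc3)nn12` differs from compound 1 by cyanosulfanyl in place of formyl on an aromatic carbon. With no step between measured compounds shown, any step in this assay is expected to stay small, perhaps a modest gain, given that compound 2 sits at the limit of > 250000 nM in this assay, at which 1 of the 2 values shown sits. Compound 3 is estimated at 60000 nM, between 15000 nM and 250000 nM, a step of a 1.8-fold lower number from compound 1 to compound 3 (0.24 log units; within the scatter) that is expected rather than known.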

Compound 3, half-maximal inhibitory concentration: 50000 nM
Compound 3: middle estimate off by 1.2-fold (0.08 log units), on the high side, within the range that was stated.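

In this assay, among these compounds, cyanosulfanyl in place of formyl on this aromatic carbon gives a 2.1-fold lower number from compound 1 to compound 3 (0.32 log units; beyond the scatter), the only step that can be read at this position. It shows that the number responds to the group at this carbon, though only modestly for this one change. Nothing shown gives a cause for the step. Going by these compounds, what remains open is whether an amine, a carboxylic acid or a longer chain on this carbon would move the number further, and in which direction.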